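A few compounds are considered here, and "the series" means these few. Any claim that something is new, unique, unknown or untested is made for them only; others in the source may bear on it.

Measured compounds:
compound 1 `Cn1ccc2nccc(NC(=O)NCCN3CCC(O)(Cc4ccccc4)CC3)c21` — 600 nM in an assay on HEK293 cells for displacement of a labelled ligand from Urotensin-2 receptor (Homo sapiens); a higher number here means a weaker inhibitor, a lower number a stronger inhibitor
compound 2 `Cn1cnc2c(NC(=O)NCCN3CCC(O)(Cc4ccccc4)CC3)ccnc21` — 2140 nM in this assay
compound 3 `Cc1cc2nccc(NC(=O)NCCN3CCC(O)(Cc4ccccc4)CC3)c2s1` — 78 nM in this assay

Compound 3 gives the lowest number of the three. The step of a 7.7-fold lower number from compound 1 to compound 3 (0.89 log units; beyond the scatter) and the step of a 27-fold lower number from compound 2 to compound 3 (1.44 log units; beyond the scatter) both set it clearly apart; the step of a 3.6-fold higher number from compound 1 to compound 2 (0.55 log units; beyond the scatter) runs the other way. Each of those three steps swaps the whole two-ring group on the amide-type nitrogen for one with a different set of hetero atoms.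

Compound 4 `O=C(NCCN1CCC(O)(Cc2ccccc2)CC1)Nc1ccnc2sccc12` keeps the sulfur-containing two-ring group of compound 3 but drops one carbon from it: a group of 9 heavy atoms (7 carbon, 1 nitrogen, 1 sulfur; one five-membered aromatic ring with 1 hetero atom, one six-membered aromatic ring with 1 hetero atom) in place of a group of 10 heavy atoms (8 carbon, 1 nitrogen, 1 sulfur; one five-membered aromatic ring with 1 hetero atom, one six-membered aromatic ring with 1 hetero atom), on an amide-type nitrogen.

Within the data shown here, none of the measured steps removes or adds a single carbon on an otherwise unchanged two-ring group, so no step bears directly on this change. The measured steps show that the two-ring group matters, but they say nothing about the missing carbon. The expectation is therefore a small step, near or just beyond the scatter, toward a higher number: a 1.9-fold higher number from compound 3 to compound 4 (0.28 log units; within the scatter). Compound 4 is estimated at 150 nM, within 50 nM to 500 nM.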

Compound 4, half-maximal inhibitory concentration: 930 nM
Compound 4: middle estimate off by 6.2-fold (0.79 log units), on the low side; measured number outside the range, above it.
By their numbers in this assay, from the lowest: compound 3; then compounds 1 and 4 (each within the scatter of the next); then compound 2.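

In this assay, the two-ring group on the amide-type nitrogen proves far less forgiving than a one-carbon difference suggests: the sulfur-containing group of 9 heavy atoms gives a large step (a 12-fold higher number from compound 3 to compound 4 (1.08 log units; beyond the scatter)), so sulfur in the group does not by itself secure the low number of compound 3. That step leaves compound 4 level with the nitrogen-containing group of compound 1 (a 1.6-fold higher number from compound 1 to compound 4 (0.19 log units; within the scatter)), though still apart from compound 2 (a 2.3-fold lower number from compound 2 to compound 4 (0.36 log units; beyond the scatter)). No measured evidence accounts for the size of the step.

From the compounds shown here alone, the step swaps the whole group, so how much of it belongs to the methyl group of compound 3 and how much to the rest of that group stays open. Whether an ethyl group or a chlorine atom in place of that methyl would hold the number of compound 3 is also unresolved.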